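The source may report more compounds than this note shows. Statements on the series, on what has been measured and on what is new or still open speak of the compounds shown alone.

Compound 1 `Cc1c(OCCCCOc2ccc(C(=O)O)cc2Cl)ccc(C(=O)CC2CCCC2)c1O`, compound 2 `Cc1ccc(C(=O)O)cc1OCCCCOc1ccc(C(=O)CC2CCCC2)c(O)c1C` and compound 3 `Cc1c(OCCCCOc2ccc(C(=O)O)c(Cl)c2)ccc(C(=O)CC2CCCC2)c1O` share one core and differ only in the carboxy-bearing phenyl group attached through an oxygen on a saturated carbon. In an ADME assay on a cell-free system (plasma, Rattus norvegicus) for metabolic stability, read by LC-MS, with a stated time of 60 min, tested at 100 uM (a higher number here means that more of the compound is left, a lower number that less of the compound is left), compound 1 gives 120%, compound 2 gives 100% and compound 3 gives 97%. The data show a number 3 percentage points lower from compound 2 to compound 3 (within the scatter), so those two stand level, while a number 23 percentage points lower from compound 1 to compound 3 (beyond the scatter) sets the remaining compound apart.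

Compound 4 `Cc1cc(OCCCCOc2ccc(C(=O)CC3CCCC3)c(O)c2C)ccc1C(=O)O` has not yet been measured. It differs from compound 3 by one swap, methyl in place of chloro on an aromatic carbon, turning 4-carboxy-3-chlorophenyl into 4-carboxy-3-methylphenyl.

Going by the values given here, no measured step makes exactly this swap, so the evidence is indirect. Two steps also trade a chloro-bearing group for a methyl-bearing one or the reverse, though with the groups placed differently. One is a number 3 percentage points lower from compound 2 to compound 3 (within the scatter), and the other is the modest a number 20 percentage points lower from compound 1 to compound 2 (beyond the scatter). The first is the closer guide, since both of its compounds lack the arrangement that sets the remaining compound apart, so no shift beyond the scatter is expected in this assay. The expected step is a number 3 percentage points higher from compound 3 to compound 4 (within the scatter). For compound 4 the estimated value is 100%, with an expected range from 85% to 115%.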

Compound 4, percent of the compound remaining: 114%
Compound 4: the middle estimate sits 14 percentage points below what was measured; measured number inside the range.
By their numbers in this assay, from the lowest: compounds 3 and 2 (each within the scatter of the next); then compounds 4 and 1 (each within the scatter of the next).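

In this assay, going by these compounds alone, this is the first direct look at methyl in place of chloro on the aromatic carbon ortho to the carboxy group, and it gives a number 17 percentage points higher from compound 3 to compound 4 (beyond the scatter) on a swap of one heavy atom for one heavy atom, so what sits on this carbon can shift the read-out, which the earlier comparisons, with their groups placed differently, could not isolate. The site of the methyl also counts, for compounds 2 and 4 both carry a methyl on the carboxy-bearing phenyl, yet there is a number 14 percentage points higher from compound 2 to compound 4 (beyond the scatter) and the two no longer stand level, while a number 6 percentage points lower from compound 1 to compound 4 (within the scatter) leaves compound 1 no longer set apart from the others. Nothing in the data gives a reason for either shift.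

What the compounds shown leave open is how other groups on this same aromatic carbon, such as fluoro, methoxy or a plain hydrogen, would read in this assay against methyl and chloro. Also open, as far as these compounds go, is whether methyl in place of chloro would give a step of similar size when made on the 4-carboxy-2-chlorophenyl group of compound 1.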